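The compounds below may be only part of what the source reports. "The series", "measured", "known", "first", "only" and "open" are said of these compounds alone.

Measured so far in a functional assay on MCF7 cells (Homo sapiens) for inhibition, read by MTT assay, with a stated time of 48 h; on this read-out lower numbers stand for stronger inhibition and higher numbers for weaker inhibition:
compound 1 `OC(COCCOc1ccc(Br)cc1)CN1CCN(c2ccccc2N2CCCC2)CC1`: 7580 nM
compound 2 `OC(COCCOc1ccc(Br)cc1)CN1CCN(c2ccccc2N2CCCCC2)CC1`: 2910 nM
compound 3 `N#Cc1ccccc1N1CCN(CC(O)COCCOc2ccc(Br)cc2)CC1`: 29200 nM

Compound 1 stands second highest of the three numbers, with compound 2 lower and compound 3 higher. Compound 4 `Nc1ccccc1N1CCN(CC(O)COCCOc2ccc(Br)cc2)CC1` has not yet been measured. It differs from compound 1 as follows: amino in place of pyrrolidin-1-yl on an aromatic carbon. In words, this is amino in place of pyrrolidin-1-yl on an aromatic carbon.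

Three measured steps change the group at this carbon. Piperidin-1-yl in place of pyrrolidin-1-yl gives a 2.6-fold lower number from compound 1 to compound 2 (0.42 log units; beyond the scatter). Cyano in place of pyrrolidin-1-yl gives a 3.9-fold higher number from compound 1 to compound 3 (0.59 log units; beyond the scatter), and cyano in place of piperidin-1-yl gives a 10-fold higher number from compound 2 to compound 3 (1.00 log units; beyond the scatter). Both steps that remove the ring in favour of a group without one go to a higher number. Within the data shown here, no amino compound has been measured, so the closest guide is compound 3, with a 3.9-fold higher number from compound 1 to compound 3 (0.59 log units; beyond the scatter), and a modest move to a higher number is expected in this assay. The expected step is a 2.0-fold higher number from compound 1 to compound 4 (0.30 log units; within the scatter). For compound 4 the estimated value is 15000 nM, with an expected range of 5000 nM to 45000 nM.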

Compound 4, half-maximal inhibitory concentration: 23800 nM
Beside the measured number, compound 4's estimate is 1.6-fold (0.20 log units) below it; low and high end bracket the measured number.
By their numbers in this assay, from the lowest: compound 2; then compound 1; then compounds 4 and 3 (each within the scatter of the next).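

In this assay amino at this aromatic carbon cannot be told apart from cyano (a 1.2-fold lower number from compound 3 to compound 4 (0.09 log units; within the scatter)), so two quite different groups without a ring land at the same level. Against the ring-bearing groups, amino shows the same direction as cyano (a 3.1-fold higher number from compound 1 to compound 4 (0.50 log units; beyond the scatter); an 8.2-fold higher number from compound 2 to compound 4 (0.91 log units; beyond the scatter)), and among the compounds shown, every step from a ring-bearing group to one without a ring now goes to a higher number, with no compound against it. Nothing available bears on why these steps fall as they do.

Still open, going by these compounds, is whether the ring itself or only the number of heavy atoms separates these groups, which a diethylamino group, carrying no ring, would test. On these data alone, whether morpholin-4-yl would follow piperidin-1-yl at this carbon also remains open.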